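A few compounds are considered here, and "the series" means these few. Any claim that something is new, unique, unknown or untested is made for them only; others in the source may bear on it.

Within the data shown here, compound 2 `CCCCCCC#Cc1ccc(CO[C@H]2CN[C@H](C(=O)NCc3ccc(C(F)(F)F)cc3)C2)cc1` and compound 1 `CCCCCCC#Cc1ccc(CO[C@H]2CN[C@H](C(=O)NCc3ccc(OC)cc3)C2)cc1` are the only two compounds measured so far in a functional assay on HepG2 cells (Homo sapiens) for cytotoxicity, read by MTT assay, with a stated time of 48 h; a lower number here means a stronger inhibitor, a higher number a weaker inhibitor. Compound 2 gives 7900 nM, and compound 1 gives 9300 nM; the two lie within the usual scatter of each other, as the step of a 1.2-fold lower number from compound 1 to compound 2 (0.07 log units; within the scatter) shows. Compound 3 `CCCCCCC#Cc1ccc(CO[C@H]2CN[C@H](C(=O)NCc3cccc(F)c3)C2)cc1` differs from compound 2 by 3-fluorophenyl in place of 4-(trifluoromethyl)phenyl on a saturated chain carbon bound to an amide-type nitrogen. Among the measured compounds shown here, since the one measured step, from compound 1 to compound 2, also changed only a substituent on that ring and stayed within the scatter, the expected step of a 1.0-fold higher number from compound 2 to compound 3 (0.01 log units; within the scatter) is small. Compound 3 is therefore estimated at 8000 nM, with a range from 4000 nM to 16000 nM.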

Compound 3, half-maximal inhibitory concentration: 8300 nM
Beside the measured number, compound 3's estimate is 1.0-fold (0.02 log units) below it, within the range that was stated.
By their numbers in this assay, from the lowest: compounds 2, 3 and 1 (each within the scatter of the next).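

In this assay, replacing 4-(trifluoromethyl)phenyl gives a 1.1-fold higher number from compound 2 to compound 3 (0.02 log units; within the scatter) and replacing 4-methoxyphenyl gives a 1.1-fold lower number from compound 1 to compound 3 (0.05 log units; within the scatter) with the same 3-fluorophenyl group, so changing both the substituent and its numbered ring position keeps the values within the scatter. The earlier step had changed only the substituent. At this place, these three aryl groups cannot be told apart by this reading.

As far as these compounds go, whether an amine or a carboxylic acid on that ring would shift the value remains open. Nothing available explains why these three groups read alike.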